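The source may hold more compounds than are shown below. What is called first, only, known or untested is meant among the compounds shown, and "the series" means these compounds.

Of the compounds shown here, two have been measured so far in an in vitro ADME assay on microsomes from liver (Homo sapiens) for pharmacokinetics, read by LC-MS, with a stated time of 10 min, tested at 1 uM; a higher number here means faster removal of the compound, a lower number slower removal. Compound 1 `CN1C[C@H](C(=O)Nc2cccc(F)c2)[C@@H](c2ccc(/C=C/C(=O)Nc3ccccc3N)cc2)C1` gives 6 mL/min/kg, while compound 2 `CN1C[C@H](C(=O)Nc2ccc(F)c(Cl)c2)[C@@H](c2ccc(/C=C/C(=O)Nc3ccccc3N)cc2)C1` gives 15 mL/min/kg, the higher of the two numbers. The next compound is compound 3 `CN1C[C@H](C(=O)Nc2ccc(Cl)c(Cl)c2)[C@@H](c2ccc(/C=C/C(=O)Nc3ccccc3N)cc2)C1`, and the structural difference from compound 2 is small: chloro in place of fluoro on an aromatic carbon. In words, chloro takes the place of fluoro on an aromatic carbon, so that 3-chloro-4-fluorophenyl becomes 3,4-dichlorophenyl.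

Going by the values given here, only one measured step offers guidance, a 2.5-fold higher number from compound 1 to compound 2 (0.40 log units; beyond the scatter). It is a modest step, and it also changed this same group, from 3-fluorophenyl to 3-chloro-4-fluorophenyl. Among the compounds with values here, it is weak evidence, however, since no measured pair shows chloro in place of fluoro alone, and a single step establishes no trend. The direction of that step suggests leaning upward, but replacing one atom is a smaller change than that step made. The expected step is a 1.3-fold higher number from compound 2 to compound 3 (0.12 log units; within the scatter), small in size and tilted towards a higher number. For compound 3 the estimated clearance is 20 mL/min/kg, with an expected range of 10 mL/min/kg to 38 mL/min/kg.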

Compound 3, clearance: 14 mL/min/kg
The estimate for compound 3 lay 1.4-fold (0.15 log units) above the measured number, and the stated range covers the measured number.
By their numbers in this assay, from the lowest: compound 1; then compounds 3 and 2 (each within the scatter of the next).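

In this assay, putting chloro in place of fluoro on the aromatic carbon para to a large group gives a 1.1-fold lower number from compound 2 to compound 3 (0.03 log units; within the scatter), so at this position, ortho to a chloro group, this read-out does not tell the two halogens apart. Compound 3 also stands clear of the compound with the simplest ring, with a 2.3-fold higher number from compound 1 to compound 3 (0.37 log units; beyond the scatter) as the step, and this matches a 2.5-fold higher number from compound 1 to compound 2 (0.40 log units; beyond the scatter) in direction: both compounds with a second halogen on the ring give higher numbers than compound 1, while neither can be ranked against the other. Nothing available here explains why fluoro and chloro fall so close together at this position.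

The step from 3-fluorophenyl to 3,4-dichlorophenyl changes the ring in more than one way, so the compounds shown do not say how much of the rise belongs to each change. They also leave open whether the closeness seen here extends beyond halogens, for example to a methoxy, a methyl or a nitrile on the same aromatic carbon.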